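The source may hold more compounds than are shown below. What is called first, only, known or untested is meant among the compounds shown, and "the series" means these compounds.

In a functional assay on A549 cells (Homo sapiens) for antiproliferative activity, read by MTT assay, with a stated time of 72 h (a lower number here means a stronger inhibitor, a higher number a weaker inhibitor), the three measured compounds give these numbers:

compound 1 `O=C1COc2ccc(-c3cccc(NS(=O)(=O)c4ccc(F)cc4)c3)cc2N1` gives 32100 nM
compound 2 `CC(C)N1C(=O)COc2ccc(-c3cccc(NS(=O)(=O)c4ccc(F)cc4)c3)cc21` gives 29400 nM
compound 3 `COc1ccc(N2C(=O)COc3ccc(-c4cccc(NS(=O)(=O)c5ccc(F)cc5)c4)cc32)cc1` gives 38200 nM

Compound 3 has the highest of the three numbers, but only just: the step of a 1.2-fold higher number from compound 1 to compound 3 (0.08 log units; within the scatter) and the step of a 1.3-fold higher number from compound 2 to compound 3 (0.11 log units; within the scatter) both stay within the scatter, as does the step of a 1.1-fold lower number from compound 1 to compound 2 (0.04 log units; within the scatter). So far, then, swapping the group on the amide-type nitrogen of the shared core, from hydrogen to isopropyl to 4-methoxyphenyl, has left this assay essentially unmoved.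

Compound 4 `O=C1COc2ccc(-c3cccc(NS(=O)(=O)c4ccc(F)cc4)c3)cc2N1c1ccc(F)cc1` keeps the aryl group on that nitrogen and alters it: fluoro in place of methoxy on an aromatic carbon. Going by the values given here, no measured step touches this aryl ring; the three known steps all concern what sits on the nitrogen itself, and each was within the scatter. There is therefore nothing in the data to predict a shift in either direction, and the expected step is a 1.0-fold lower number from compound 3 to compound 4 (0.00 log units; within the scatter), within the scatter. Compound 4 is estimated at 38000 nM, with a range from 19000 nM to 76000 nM.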

Compound 4, half-maximal inhibitory concentration: > 40000 nM
Compound 4: a limit, no number (the forecaster's own chance of this, stated with the estimate: 10%); middle value at least 1.0-fold (0.02 log units) away from the limit.
By their numbers in this assay, from the lowest: compounds 2, 1 and 3 (each within the scatter of the next). At a limit, above all of these: compound 4.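

In this assay, compound 4 gives no number, only a limit of the assay: the limit of > 40000 nM in this assay, at which 1 of the 4 values shown sits. From the compounds shown here alone, the steps can therefore be read only as floors, an at least 1.0-fold higher number from compound 3 to compound 4 (0.01 log units; that floor lies within the scatter), an at least 1.3-fold higher number from compound 2 to compound 4 (0.13 log units; that floor lies within the scatter) and an at least 1.2-fold higher number from compound 1 to compound 4 (0.09 log units; that floor lies within the scatter), and the real size of each remains unknown. The earlier compounds shown here varied only the group on the nitrogen, whereas this change reaches the aromatic carbon para to a large group, and 4-fluorophenyl in place of 4-methoxyphenyl gives no sign of a lower number.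

Going by these compounds, how far compound 4 lies beyond its limit stays open, so this change may be small or large. Also open, on these data alone, is whether another group on this aromatic carbon, such as an amine or a carboxylic acid, would bring the number down.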